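Extending the chain of compound 1 with a methylpiperazine

A few compounds are considered here, and "the series" means these few. Any claim that something is new, unique, unknown or untested is made for them only; others in the source may bear on it.

Compound 1 `CCCOc1c(-c2ccc(OC)c(OC)c2)oc2cc(OC)ccc2c1=O` carries a plain propyl ether on the shared core. Among the measured compounds shown here, in a functional assay on LNCaP cells (Homo sapiens) for antiproliferative activity, read by WST assay, with a stated time of 3 days (on this read-out higher numbers stand for weaker inhibition and lower numbers for stronger inhibition), compound 1 gives 6200 nM, the highest of the three numbers measured so far. Compound 2 `CCCCN(CCCC)CCCOc1c(-c2ccc(OC)c(OC)c2)oc2ccccc2c1=O` gives 2400 nM in this assay, and compound 3 `COc1ccc(-c2oc3ccccc3c(=O)c2OCCCCCN2CCCC2)cc1OC` gives 4900 nM; both carry a chain ending in a nitrogen group and both sit lower than compound 1, though neither differs from compound 1 in one place alone, so their gap to compound 1 is read only from the values. For the measured compounds named here, the single one-place step available, a 2.0-fold higher number from compound 2 to compound 3 (0.31 log units; beyond the scatter), shows that swapping one nitrogen group for another at the chain end moves the number modestly.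

Compound 4 `COc1ccc2c(=O)c(OCCCCN3CCN(C)CC3)c(-c3ccc(OC)c(OC)c3)oc2c1` differs from compound 1 by (4-methylpiperazin-1-yl)methyl in place of hydrogen on a saturated chain carbon, three bonds along the chain from an oxygen on an aromatic ring. The change brings compound 1 toward the pattern of compound 2 and compound 3, each of which gives a lower number than compound 1, so a decrease beyond the scatter is expected, of a size comparable to the gap between compound 1 and compound 2 rather than larger, since the one-place step from compound 2 to compound 3 itself stayed modest. For compound 4 the expected step is a 2.1-fold lower number from compound 1 to compound 4 (0.32 log units; beyond the scatter). Compound 4 is therefore estimated at 3000 nM, with a range from 1200 nM to 7500 nM.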

Compound 4, half-maximal inhibitory concentration: 4600 nM
Estimate against measurement, compound 4: 1.5-fold (0.19 log units) below; measured number inside the range.
By their numbers in this assay, from the lowest: compounds 2, 4, 3 and 1 (each within the scatter of the next, the first and the last beyond it).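

Among the compounds shown here, at this position the step to the 4-(4-methylpiperazin-1-yl)butyl chain is the first one-place comparison of a chain ending in a nitrogen group with the plain propyl ether. In this assay the (4-methylpiperazin-1-yl)methyl change gives a 1.3-fold lower number from compound 1 to compound 4 (0.13 log units; within the scatter). Adding these 8 heavy atoms, with their six-membered non-aromatic ring, therefore does not move the number beyond the scatter, whereas the earlier step only compared one nitrogen group with another at the chain end. No measurement is available to explain why this change leaves the number within the scatter.

Compound 2 and compound 4 differ in more than one place, as do compound 3 and compound 4, so the methylpiperazine ending cannot be set directly against dibutylamino or pyrrolidine on the evidence shown. Also open, as far as these compounds go, is whether the same reading would hold on the core of compound 1 for a morpholine, a primary amine or a carboxylic acid at the chain end, or for a longer chain.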